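From pyridin-2-yl to pyridin-3-yl: a cytotoxicity limit

This account rests on a few compounds, and the source may have more. Where it says the series, first, only, none or still open, it means among the compounds named here.

Compound 1 `Cc1nc(C)c([C@H](OC(C)(C)C)C(=O)O)c(N2CCC(C)(C)CC2)c1-c1ccc(OCCc2ccc(F)cc2F)cc1`, compound 2 `Cc1nc(C)c([C@H](OC(C)(C)C)C(=O)O)c(N2CCC(C)(C)CC2)c1-c1ccc(OCCc2ccc(F)c(F)c2)cc1` and compound 3 `Cc1nc(C)c([C@H](OC(C)(C)C)C(=O)O)c(N2CCC(C)(C)CC2)c1-c1ccc(OCCc2ccccn2)cc1` share one core and differ only in the ring at the end of a side chain. In a toxicity assay on MT2 cells (Homo sapiens) for cytotoxicity, read by XTT assay, with a stated time of 4 days (a higher number here means that more compound is tolerated, a lower number that less compound is tolerated), compound 3 gives >= 25000 nM, which is a limit of the assay and not a number. Compound 1 gives >= 33500 nM, also a limit. Compound 2 gives >= 33500 nM, again a limit. Compound 3 therefore has no exact value, and neither of the other two offers one for comparison.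

Compound 4 `Cc1nc(C)c([C@H](OC(C)(C)C)C(=O)O)c(N2CCC(C)(C)CC2)c1-c1ccc(OCCc2cccnc2)cc1` has the same atoms as compound 3, joined differently: pyridin-3-yl in place of pyridin-2-yl on a saturated chain carbon, two bonds along the chain from an oxygen on an aromatic ring. In words, pyridin-3-yl takes the place of pyridin-2-yl on a saturated chain carbon, two bonds along the chain from an oxygen on an aromatic ring.

Three measured changes at this same place bear on the new one: a step that the two limits leave unreadable from compound 1 to compound 3, a step that the two limits leave unreadable from compound 2 to compound 3 and a step that the two limits leave unreadable from compound 1 to compound 2. None of them has a readable size, so none points in a direction. No step beyond the scatter is therefore expected in this assay. The estimated change is a step that the limit leaves unreadable from compound 3 to compound 4. For compound 4 the expected value is 30000 nM, within an estimated range from 15000 nM to 60000 nM, and the assay will probably report a limit again.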

Compound 4, half-maximal cytotoxic concentration: >= 25000 nM
Compound 4 was reported as a limit (the forecaster's own chance of this, stated with the estimate: 85%); the middle value is on the limit's open side.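

In this assay compound 4 is reported only as a limit and not as a number, as are compound 1, compound 2 and compound 3, so no step among these four compounds can be read. The compounds shown leave open how much of each compound the cells tolerate, and whether pyridin-3-yl and pyridin-2-yl differ at all here.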